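Aryl swap on the shared core: compound 2 to compound 3

A few compounds are considered here, and "the series" means these few. Any claim that something is new, unique, unknown or untested is made for them only; others in the source may bear on it.

Compound 2 `Fc1ccc(-c2cn3ccnc3c(-c3ccc4ncn(C5CCCCC5)c4c3)n2)cc1` and compound 1 `O=Cc1ccc(-c2cn3ccnc3c(-c3ccc4ncn(C5CCCCC5)c4c3)n2)cc1` share one core and differ only in the group set on an aromatic carbon of that core. In a functional assay on UACC-62 cells (Homo sapiens) for inhibition, read by sulforhodamine B assay, with a stated time of 48 h, tested at 10 uM (on this read-out higher numbers stand for more inhibition at the one concentration tested (going by the name of the read-out) and lower numbers for less inhibition), compound 1 gives 37.1%, and in this assay compound 2 gives 31%. The step of a number 6.1 percentage points lower from compound 1 to compound 2 (within the scatter) lies within the scatter, so the two values show no real order; compound 2 merely holds the smaller of the two numbers recorded, with compound 1 as its only and nearest comparator.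

Compound 3 `FC(F)(F)c1cccc(-c2cn3ccnc3c(-c3ccc4ncn(C5CCCCC5)c4c3)n2)c1` carries the change (3-(trifluoromethyl)phenyl in place of 4-fluorophenyl on an aromatic carbon). Among the compounds with values here, no measured step covers this exchange of aryl groups. Within the data shown here, the only step available, a number 6.1 percentage points lower from compound 1 to compound 2 (within the scatter), concerns a different exchange on an aromatic carbon and stayed within the scatter, which gives no ground to expect a shift beyond the scatter in this assay for compound 3. The estimate for compound 3 in this assay is therefore 33%, with a range from 15% to 52%. The step expected from this estimate, a number 2 percentage points higher from compound 2 to compound 3 (within the scatter), is none beyond the scatter.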

Compound 3, a percentage reported as inhibition, at one concentration (the size of the read-out at that concentration, not a potency): 4.33%
Compound 3: the middle estimate sits 28.7 percentage points above what was measured; measured number below the stated range.
By their numbers in this assay, from the lowest: compound 3; then compounds 2 and 1 (each within the scatter of the next).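

In this assay, this aromatic carbon of the shared core now shows a real response to the aryl group: 3-(trifluoromethyl)phenyl in place of 4-fluorophenyl gives a clear loss of inhibition at the one concentration tested (a number 26.7 percentage points lower from compound 2 to compound 3 (beyond the scatter)), and the same group in place of 4-formylphenyl gives a larger printed step (a number 32.8 percentage points lower from compound 1 to compound 3 (beyond the scatter)). The earlier pair gave no such signal (a number 6.1 percentage points lower from compound 1 to compound 2 (within the scatter)), so the 4-formylphenyl and 4-fluorophenyl groups could not be told apart, while compound 3 falls clearly under both, which means this position is not indifferent to the exchange of aryl groups. No measurement at hand gives a cause for this drop.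

The step changes the substituent and its place on the phenyl ring together, so a 4-(trifluoromethyl)phenyl group at this carbon would be needed to tell those two changes apart. On these data alone, how an amine or a carboxylic acid on that phenyl ring would read in this assay also remains open.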